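The source may report more compounds than this note shows. Statements on the series, on what has been measured and on what is new or still open speak of the compounds shown alone.

Measured compounds in a physicochemical assay for solubility; a higher number here means a more soluble compound, a lower number a less soluble compound:
Compound 1 `O=C(O)c1ccc(C(=O)/C(=C\c2ccc(F)c([N+](=O)[O-])c2)Sc2ccc(Br)cc2)cc1` gives < 1000 ug/mL, a limit of the assay and not a number.
Compound 2 `O=C(O)c1ccc(C(=O)/C(=C\c2ccc(O)c(Br)c2)SCc2ccc(Br)cc2)cc1` gives < 1000 ug/mL, again only a limit.
Compound 3 `O=C(O)c1ccc(C(=O)/C(=C\c2ccc(F)c([N+](=O)[O-])c2)SCc2ccccc2)cc1` gives < 1000 ug/mL, again only a limit.

Compound 2 therefore stands where every value here stands, at the limit of < 1000 ug/mL in this assay, at which 3 of the 3 values shown sit, and no number for it is known. Among the compounds with values here, the single step between measured compounds, a step that the two limits leave unreadable from compound 1 to compound 3, concerns the group on the sulfur and does not touch the change now followed. Compound 4 `O=C(O)c1ccc(C(=O)/C(=C\c2cc([N+](=O)[O-])ccc2F)SCc2ccc(Br)cc2)cc1` differs from compound 2 by 2-fluoro-5-nitrophenyl in place of 3-bromo-4-hydroxyphenyl on a double-bonded chain carbon bound to a double-bonded chain carbon. Within the data shown here, no measured step bears on this change, and with all three values sitting at the same limit no size or direction can be read from them. The step that the limit leaves unreadable from compound 2 to compound 4 is expected to be small, within the scatter. Compound 4 is expected at 300 ug/mL, in the range 50 ug/mL to 1000 ug/mL, most likely again reported only as a limit.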

Compound 4, solubility: < 1000 ug/mL
Compound 4: only a limit was reported; the forecaster's own chance of this, stated with the estimate: 85%; the middle value is on the limit's open side.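

In this assay compound 4 gives < 1000 ug/mL, a limit and not a number, so no step from compound 2 to compound 4 can be read: the limit of < 1000 ug/mL in this assay, at which 4 of the 4 values shown sit.

As far as these compounds go, the size and direction of the exchange of 3-bromo-4-hydroxyphenyl for 2-fluoro-5-nitrophenyl remain open.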